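Methoxy in place of fluoro on a shared core

The source may hold more compounds than are shown below. What is called first, only, known or untested is meant among the compounds shown, and "the series" means these compounds.

Two compounds in this set carry measured numbers. Compound 1 `Nc1cc(N)c2nc(-c3ccccc3)c(Sc3ccc(F)cc3)nc2c1` and compound 2 `CCOC(=O)[C@H](CCC(=O)O)NC(=O)c1ccc(Oc2nc3cc(N)cc(N)c3nc2-c2ccccc2)cc1` were both run in a functional assay on NCI-H23 cells (Homo sapiens) for inhibition, read by sulforhodamine B assay, with a stated time of 48 h; on this read-out higher numbers stand for weaker inhibition of growth and lower numbers for stronger inhibition of growth. In this assay compound 1 gives 19100 nM, the highest of the two numbers, and compound 2 gives 15500 nM; the two values sit within the usual scatter of each other, so nothing separates them. Compound 3 `COc1ccc(Sc2nc3cc(N)cc(N)c3nc2-c2ccccc2)cc1` has not yet been measured. It differs from compound 1 in a single place: methoxy in place of fluoro on an aromatic carbon. For the measured compounds named here, no pair of measured compounds that differ in one place is available, so this exchange has no precedent within the set. Since compound 1 stands at 19100 nM and the rest of the molecule is untouched, the account expects at most a small step, a 1.3-fold lower number from compound 1 to compound 3 (0.10 log units; within the scatter), with no direction beyond the scatter. Compound 3 is therefore estimated at 15000 nM in this assay, with a range from 5000 nM to 45000 nM.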

Compound 3, concentration for 50% growth inhibition: < 100000 nM
Compound 3: only a limit was reported; the forecaster's own chance of this, stated with the estimate: 10%; the middle value does not contradict the limit.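

In this assay compound 3 gives < 100000 nM, which is a limit and not a number. For the compounds shown here, no step can therefore be read between compound 1 and compound 3. The compounds shown leave open whether methoxy in place of fluoro on an aromatic carbon changes the inhibition of growth at all, and in which direction.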